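The source may report more compounds than this note shows. Statements on the series, on what has been measured and on what is new or still open speak of the compounds shown alone.

Measured so far in a functional assay on PANC-1 cells (Homo sapiens) for inhibition, read by MTT assay, with a stated time of 72 h; on this read-out higher numbers stand for weaker inhibition of growth and lower numbers for stronger inhibition of growth:
compound 1 `CC(C)(C)c1ccc(CNCCCNS(=O)(=O)c2cc(C(F)(F)F)cc(C(F)(F)F)c2)cc1` gives 2500 nM
compound 2 `O=S(=O)(NCCCNCc1ccc(Cl)c(Cl)c1)c1cc(C(F)(F)F)cc(C(F)(F)F)c1` gives 5600 nM

Compound 1 stands at the lower of the two numbers in this assay. Within the data shown here, the single measured step, a 2.2-fold higher number from compound 1 to compound 2 (0.35 log units; beyond the scatter), came from putting 3,4-dichlorophenyl in place of 4-(tert-butyl)phenyl on the saturated chain carbon bound to the amine nitrogen, with the shared core left untouched.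

Compound 3 `O=S(=O)(NCCCNCC1COc2ccccc2O1)c1cc(C(F)(F)F)cc(C(F)(F)F)c1` differs from compound 1 at that same place: 2,3-dihydro-1,4-benzodioxin-2-yl in place of 4-(tert-butyl)phenyl on a saturated chain carbon bound to an amine nitrogen. Among the measured compounds shown here, only the step from compound 1 to compound 2 bears on this change, and only loosely, since it swapped one aryl group for another aryl group, whereas here the entering group carries a non-aromatic ring with two hetero atoms. That step was modest and beyond the scatter, and a rise of similar size in this assay is expected here, a 2.0-fold higher number from compound 1 to compound 3 (0.30 log units; within the scatter). Compound 3 is therefore expected to give about 5000 nM, with a range from 2000 nM to 15000 nM.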

Compound 3, concentration for 50% growth inhibition: 3400 nM
Beside the measured number, compound 3's estimate is 1.5-fold (0.17 log units) above it; the measured number falls inside the stated range.
By their numbers in this assay, from the lowest: compounds 1, 3 and 2 (each within the scatter of the next, the first and the last beyond it).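

In this assay this place on a saturated chain carbon bound to an amine nitrogen also takes a group that is not a plain substituted phenyl: with 2,3-dihydro-1,4-benzodioxin-2-yl, which brings a non-aromatic ring with 2 hetero atoms and 2 hydrogen-bond acceptors, the result is a 1.4-fold higher number from compound 1 to compound 3 (0.13 log units; within the scatter) and a 1.6-fold lower number from compound 2 to compound 3 (0.22 log units; within the scatter). Compound 3 therefore cannot be told apart from either earlier compound, even though those two stand beyond the scatter of each other. No measured evidence bearing on the reason for this result is available.

The compounds shown leave open how a carboxylic acid or a pyridine ring would read at this place. They also leave open whether the two ring oxygens matter, which a matching all-carbon ring such as tetralin would test.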